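A few compounds are considered here, and "the series" means these few. Any claim that something is new, unique, unknown or untested is made for them only; others in the source may bear on it.

Compound 1 `C[C@H]1CN(c2scnc2-c2nc3ccccc3[nH]2)CCN1C(=O)Cn1cnc2cccnc21` gives 8030 nM in a functional assay on U2OS cells for antagonist activity at C-X-C chemokine receptor type 3 (Homo sapiens), read by beta-arrestin recruitment; on this read-out higher numbers stand for weaker inhibition and lower numbers for stronger inhibition; compound 2 `CCOc1ncc(-c2nc(C(F)(F)F)sc2N2CCN(C(=O)Cn3ncc4cccnc43)[C@H](C)C2)cn1` gives 55 nM.

Compound 2 has the lower of the two numbers, and its gap to compound 1 lies well beyond the scatter. Compound 3 `CCOc1ncc(-c2nc(C(F)(F)F)sc2N2CCN(C(=O)Cn3nc(C)cc3C)[C@H](C)C2)cn1` keeps the core of compound 2 and differs only in a group of 7 heavy atoms (5 carbon, 2 nitrogen; one five-membered aromatic ring with 2 hetero atoms) in place of a group of 9 heavy atoms (6 carbon, 3 nitrogen; one five-membered aromatic ring with 2 hetero atoms, one six-membered aromatic ring with 1 hetero atom), on a saturated chain carbon bound to a carbonyl carbon. Going by the values given here, no step between measured compounds matches this change, so the expectation rests on compound 2 alone. Since the entering group is smaller and drops the six-membered ring, a modest weakening is expected, a 2.9-fold higher number from compound 2 to compound 3 (0.46 log units; beyond the scatter). Compound 3 is expected to give 160 nM, with a range from 40 nM to 650 nM.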

Compound 3, half-maximal inhibitory concentration: 87 nM
Compound 3: the middle estimate sits 1.8-fold (0.26 log units) above what was measured, and the stated range covers the measured number.
By their numbers in this assay, from the lowest: compounds 2 and 3 (each within the scatter of the next); then compound 1.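

On a saturated chain carbon bound to a carbonyl carbon, 3,5-dimethyl-1H-pyrazol-1-yl can replace the larger two-ring group: in this assay, the replacement gives a 1.6-fold higher number from compound 2 to compound 3 (0.20 log units; within the scatter) on the core shared by these compounds. On this core, then, the six-membered aromatic ring of the departing group is not required for a value in this range. Nothing measured here explains why the two groups read alike. From the compounds shown here alone, it remains open whether the two methyl groups are needed, and how a pyrazole without methyl groups or one carrying ethyl groups would read.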